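Replacing fluoro with ethylsulfonyl in a cytotoxic series

A few compounds are considered here, and "the series" means these few. Any claim that something is new, unique, unknown or untested is made for them only; others in the source may bear on it.

Within the data shown here, in a functional assay on MDA-MB-231 cells (Homo sapiens) for cytotoxicity, read by MTT assay, with a stated time of 24 h (on this read-out lower numbers stand for stronger inhibition and higher numbers for weaker inhibition), compound 1 `Fc1cccc(-c2nc3cccnc3n2C2CCCCC2)c1` gives 342 nM, the lower of the two numbers measured so far. Compound 2 `Cc1ccc(-c2nc3cccnc3n2C2CCCCC2)cc1` gives 7000 nM in this assay.

The unmeasured compound 3 `CCS(=O)(=O)c1cccc(-c2nc3cccnc3n2C2CCCCC2)c1` keeps the core of compound 1 but carries ethylsulfonyl in place of fluoro on an aromatic carbon, meta to a large group: ethylsulfonyl in place of fluoro on an aromatic carbon.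

Among the measured compounds shown here, only one measured step bears on this change: a 20-fold higher number from compound 1 to compound 2 (1.31 log units; beyond the scatter), a large step in which 4-methylphenyl took the place of 3-fluorophenyl. For the measured compounds named here, it shows that changing this substituted ring can shift the number strongly, but no measured compound carries ethylsulfonyl, so it is only a loose guide. On that single large step, a move towards a higher number seems more likely than a move lower. The expected step is a 3.5-fold higher number from compound 1 to compound 3 (0.55 log units; beyond the scatter), and it is uncertain. For compound 3 the estimated value is 1200 nM, with an expected range from 200 nM to 7000 nM.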

Compound 3, half-maximal inhibitory concentration: 164 nM
For compound 3 the middle estimate is 7.3-fold (0.86 log units) above the measured one; measured number below the stated range.
By their numbers in this assay, from the lowest: compound 3; then compound 1; then compound 2.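

Ethylsulfonyl in place of fluoro gives a 2.1-fold lower number from compound 1 to compound 3 (0.32 log units; beyond the scatter) in this assay, a modest step. The earlier step changed both the substituent and the ring carrying it, whereas this one changes only the group at this place, and it shows that a larger group bringing hydrogen-bond acceptors is tolerated here without the number rising. No measurement shown explains this step.

The compounds shown leave open whether the sulfonyl unit, the ethyl chain on it, or both account for the lower number, which a methylsulfonyl or propylsulfonyl group at this place could help separate. Going by these compounds, how an amine or a carboxylic acid would behave on this same aromatic carbon also remains open.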